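Swapping a Cyanofluorophenyl for a Cyanopyridinyl Group

The source may report more compounds than this note shows. Statements on the series, on what has been measured and on what is new or still open speak of the compounds shown alone.

Among the compounds with values here, in a toxicity assay on MT4 cells (Homo sapiens) for cytotoxicity, read by MTT assay, with a stated time of 5 days (on this read-out lower numbers stand for higher toxicity in this test and higher numbers for lower toxicity in this test), compound 1 `Cc1cc(-c2ccc(C#N)cc2)cc(C)c1Oc1nc(Nc2ccc(C#N)c(F)c2)nc2ccsc12` gives 71500 nM, the only outright number in this set. Compound 2 `Cc1cc(-c2ccc(C#N)cc2)cc(C)c1Oc1nc(Nc2ccc(C#N)c(F)c2)nc2sccc12` is reported in this assay only as a limit of > 254000 nM, and (the limit of > 254000 nM in this assay, at which 1 of the 2 values shown sits). Compound 3 `Cc1cc(-c2ccc(C#N)cc2)cc(C)c1Oc1nc(Nc2ccc(C#N)nc2)nc2ccsc12` differs from compound 1 by 6-cyanopyridin-3-yl in place of 4-cyano-3-fluorophenyl on a nitrogen on an aromatic ring. Within the data shown here, no measured step of this kind is available, so no size can be read from the data. The step of a 1.2-fold higher number from compound 1 to compound 3 (0.08 log units; within the scatter) is expected to stay within the usual scatter of this assay. Compound 3 is therefore estimated at 85000 nM in this assay, within 30000 nM to 250000 nM.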

Compound 3, half-maximal cytotoxic concentration: 214000 nM
Compound 3: the middle estimate sits 2.5-fold (0.40 log units) below what was measured; low and high end bracket the measured number.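

The group on a nitrogen on an aromatic ring proves able to shift the read-out in this assay: 6-cyanopyridin-3-yl in place of 4-cyano-3-fluorophenyl gives a 3.0-fold higher number from compound 1 to compound 3 (0.48 log units; beyond the scatter). Within the data shown here, this is the only measured step in the set; it is modest but beyond the scatter, and the higher number means lower toxicity in this test. Nothing measured here accounts for it. The compounds leave open whether the ring nitrogen or the absence of the fluorine carries the step. They also leave open how a methoxy group in place of the nitrile would read here.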